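The source may report more compounds than this note shows. Statements on the series, on what has been measured and on what is new or still open speak of the compounds shown alone.

Three compounds share one core and differ only in the ring at the end of a saturated chain. Compound 1 `Cc1c(C(=O)O)c(-c2cccc(N3CCN(c4ccc(NS(=O)(=O)c5ccc(N[C@H](CCN6CC(O)C6)CSc6ccccc6)c(S(=O)(=O)C(F)(F)F)c5)cc4)CC3)c2)c(-c2ccc(Cl)cc2)n1C` carries a 3-hydroxyazetidin-1-yl ring there, and in a functional assay on NCI-H1417 cells (Homo sapiens) for inhibition, read by WST assay, with a stated time of 4 days (on this read-out lower numbers stand for stronger inhibition and higher numbers for weaker inhibition), compound 1 gives 299 nM. Compound 2 `Cc1c(C(=O)O)c(-c2cccc(N3CCN(c4ccc(NS(=O)(=O)c5ccc(N[C@H](CCN6CCC(O)CC6)CSc6ccccc6)c(S(=O)(=O)C(F)(F)F)c5)cc4)CC3)c2)c(-c2ccc(Cl)cc2)n1C` carries a 4-hydroxypiperidin-1-yl ring, and in this assay compound 2 gives 125 nM. Compound 3 `Cc1c(C(=O)O)c(-c2cccc(N3CCN(c4ccc(NS(=O)(=O)c5ccc(N[C@H](CCN6CCCC6)CSc6ccccc6)c(S(=O)(=O)C(F)(F)F)c5)cc4)CC3)c2)c(-c2ccc(Cl)cc2)n1C` carries a pyrrolidin-1-yl ring, and in this assay compound 3 gives 106 nM, the lowest of the three numbers, though compound 2 sits within the scatter of it; only compound 1 stands clearly apart, as the step of a 2.8-fold lower number from compound 1 to compound 3 (0.45 log units; beyond the scatter) shows. Compound 4 `Cc1c(C(=O)O)c(-c2cccc(N3CCN(c4ccc(NS(=O)(=O)c5ccc(N[C@H](CCN6CCC6)CSc6ccccc6)c(S(=O)(=O)C(F)(F)F)c5)cc4)CC3)c2)c(-c2ccc(Cl)cc2)n1C` has not yet been measured. The change is azetidin-1-yl in place of pyrrolidin-1-yl on a saturated chain carbon, three bonds along the chain from a nitrogen on an aromatic ring. For the measured compounds named here, only one measured step touches this ring, a 2.8-fold lower number from compound 1 to compound 3 (0.45 log units; beyond the scatter), and it replaced 3-hydroxyazetidin-1-yl rather than plain azetidin-1-yl, so it speaks only indirectly to a simple shrinking of the ring. For compound 4 in this assay a small rise in the number, within or just beyond the scatter, is expected, a 1.5-fold higher number from compound 3 to compound 4 (0.18 log units; within the scatter). The estimate for compound 4 is 160 nM, with a range from 70 nM to 400 nM.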

Compound 4, half-maximal inhibitory concentration: 126 nM
Estimate against measurement, compound 4: 1.3-fold (0.10 log units) above; low and high end bracket the measured number.
By their numbers in this assay, from the lowest: compounds 3, 2 and 4 (each within the scatter of the next); then compound 1.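

In this assay, the ring on this chain can shrink from pyrrolidin-1-yl to azetidin-1-yl without a change beyond the scatter, as a 1.2-fold higher number from compound 3 to compound 4 (0.08 log units; within the scatter) shows. The earlier compounds shown here could not separate ring size from the hydroxy group, but this pair can: on the four-membered ring, swapping the hydroxy group for hydrogen alone gives a 2.4-fold lower number from compound 1 to compound 4 (0.38 log units; beyond the scatter), so the higher number of compound 1 goes with its hydroxy group rather than with the small ring. No measurement at hand explains why either step turned out as it did.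

The hydroxy step is known on this one ring only, and plain piperidin-1-yl would be needed to test it on the ring of compound 2. An open-chain amine such as dimethylamino at this place would show whether a ring is needed at all.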